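Anilide variation on a shared acid core in paw edema

The source may report more compounds than this note shows. Statements on the series, on what has been measured and on what is new or still open speak of the compounds shown alone.

Compound 1 `COc1cc2c(cc1OC)C(CC(=O)O)CC2`: 27.5%
Compound 2 `COc1cc2c(cc1OC)C(CC(=O)Nc1ccc(Cl)cc1)CC2`: 60.9%
Compound 3 `COc1cc2c(cc1OC)C(CC(=O)Nc1cccc(C)c1)CC2`: 37.7%

In a functional assay on the whole organism (strain Wistar) for inhibition, with Rattus norvegicus as the target, read by paw edema, with a stated time of 3 h, at a dose of 100 mg/kg (a higher number here means more inhibition at the dose given (going by the name of the read-out), a lower number less inhibition), compound 2 stands highest of the three measured compounds. The nearest is compound 3, reached by a number 23.2 percentage points lower from compound 2 to compound 3 (beyond the scatter); the furthest is compound 1. The step of a number 33.4 percentage points higher from compound 1 to compound 2 (beyond the scatter) is large, whereas a number 10.2 percentage points higher from compound 1 to compound 3 (beyond the scatter) is only modest. Compound 4 `COc1cc2c(cc1OC)C(CC(=O)Nc1ccc([N+](=O)[O-])cc1)CC2` differs from compound 2 by nitro in place of chloro on an aromatic carbon. Among the compounds with values here, the only measured step that bears on a change of the group on the amide-type nitrogen is a number 23.2 percentage points lower from compound 2 to compound 3 (beyond the scatter), which was modest; no measured compound carries a nitro group. The step from compound 2 to compound 4 is therefore expected to be small, at most a modest loss: a number 5.9 percentage points lower from compound 2 to compound 4 (within the scatter). Compound 4 is estimated at 55%, with a range from 35% to 72%.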

Compound 4, a percentage reported as inhibition, in the whole organism at one dose (the size of the read-out at that dose, not a potency): 37.7%
Compound 4: middle estimate off by 17.3 percentage points, on the high side; measured number inside the range.
By their numbers in this assay, from the lowest: compound 1; then compounds 3 and 4 (each within the scatter of the next); then compound 2.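

In this assay the change from chloro to nitro on the same aromatic carbon, para to a large group, gives a number 23.2 percentage points lower from compound 2 to compound 4 (beyond the scatter) and so the anilide alone does not carry the high number of compound 2. The earlier step from compound 2 to compound 3 changed both the group and its place on the ring, whereas here only the group changes, which shows that the group at this place matters by itself.

From the compounds shown here alone, whether fluoro or an amine on this carbon would stay close to compound 2 remains open. Nothing available gives a reason for the loss.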